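The source may hold more compounds than are shown below. What is called first, only, known or untested is meant among the compounds shown, and "the series" means these compounds.

Three compounds share one core and differ only in the group on the amide-type nitrogen of the hydroxyurea: compound 1 `CC(C)NC(=O)N(O)CC1=Cc2cc(Oc3ccccc3)ccc2OC1` carries an isopropyl group, compound 2 `CCCCNC(=O)N(O)CC1=Cc2cc(Oc3ccccc3)ccc2OC1` a butyl group and compound 3 `O=C(NCc1ccccc1)N(O)CC1=Cc2cc(Oc3ccccc3)ccc2OC1` a benzyl group. In an assay (Cavia porcellus) for inhibition of Polyunsaturated fatty acid 5-lipoxygenase (Homo sapiens) (on this read-out lower numbers stand for stronger inhibition and higher numbers for weaker inhibition), compound 1 gives 49 nM, compound 2 gives 65 nM and compound 3 gives 440 nM, the highest number of the three. The step of a 1.3-fold higher number from compound 1 to compound 2 (0.12 log units; within the scatter) is small, whereas a 9.0-fold higher number from compound 1 to compound 3 (0.95 log units; beyond the scatter) and a 6.8-fold higher number from compound 2 to compound 3 (0.83 log units; beyond the scatter) both stand beyond the scatter.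

Compound 4 `C=CCNC(=O)N(O)CC1=Cc2cc(Oc3ccccc3)ccc2OC1` is not yet measured. Compared with compound 3 it shows (vinyl in place of phenyl on a saturated chain carbon bound to an amide-type nitrogen). The step that bears on it most directly is a 6.8-fold higher number from compound 2 to compound 3 (0.83 log units; beyond the scatter). There a small saturated chain was exchanged for a phenyl on the same carbon and the number rose; the change to compound 4 runs in the opposite direction, taking the phenyl away and putting a small unsaturated chain in its place. The step of a 1.3-fold higher number from compound 1 to compound 2 (0.12 log units; within the scatter) adds that the small groups on this nitrogen gave similar numbers among themselves.

Compound 4 is therefore expected to show a 6.3-fold lower number from compound 3 to compound 4 (0.80 log units; beyond the scatter), a return to the region of the small-chain compounds. The estimate for compound 4 in this assay is 70 nM, with a range from 30 nM to 170 nM.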

Compound 4, half-maximal inhibitory concentration: 37 nM
The estimate for compound 4 lay 1.9-fold (0.28 log units) above the measured number, and the stated range covers the measured number.
By their numbers in this assay, from the lowest: compounds 4, 1 and 2 (each within the scatter of the next); then compound 3.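

In this assay, exchanging the phenyl of the benzyl group for a vinyl, which turns benzyl into allyl, gives a 12-fold lower number from compound 3 to compound 4 (1.08 log units; beyond the scatter) and shows that the high number of compound 3 does not carry over to a chain of similar shape that has a double bond in place of the aromatic ring. The allyl group also sits level with the saturated groups, with a 1.8-fold lower number from compound 2 to compound 4 (0.24 log units; within the scatter) and a 1.3-fold lower number from compound 1 to compound 4 (0.12 log units; within the scatter), so the double bond does not set it apart from butyl or isopropyl, and among the four groups on this nitrogen only benzyl stands out. No measurement is available that explains why benzyl behaves differently from the other three groups.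

The compounds shown leave open whether the higher number belongs to any ring on this nitrogen or to benzyl alone, which a cyclohexylmethyl or a cyclopropyl group would help to separate. They also leave open how far this nitrogen tolerates a longer chain such as octyl, or a chain ending in an amine or a carboxylic acid.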